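Heteroaryl swap on the sulfanyl chain of the urea series

The compounds below may be only part of what the source reports. "The series", "measured", "known", "first", "only" and "open" are said of these compounds alone.

Measured so far in an assay on microsomes from liver for inhibition of sterol O-acyltransferase 1 (Rattus norvegicus); a lower number here means a stronger inhibitor, a higher number a weaker inhibitor:
compound 1 `CCCCCCN(CCCCCSc1nc2c([nH]1)CCCC2)C(=O)Nc1ccc(F)cc1F`: 810 nM
compound 2 `CCCCCCCN(CCCCCSc1ncccn1)C(=O)Nc1ccc(F)cc1F`: 3300 nM
compound 3 `CCCCCCCN(CCCCCSc1nc(O)cc(Cc2ccccc2)n1)C(=O)NC(C)C`: 9200 nM

Compound 2 stands second highest of the three numbers in this assay. Compound 3 gives a higher number, and the gap lies beyond the scatter. Going by the values given here, compound 1 gives a lower number, again beyond the scatter; compound 1 differs from compound 2 in more than one place, so no single step is drawn between them.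

The step under review leads from compound 2 to compound 4 `CCCCCCCN(CCCCCSc1n[nH]c(-c2ccccc2)n1)C(=O)Nc1ccc(F)cc1F`. The change is 5-phenyl-1H-1,2,4-triazol-3-yl in place of pyrimidin-2-yl on a sulfur. The urea part and the chain stay as in compound 2.

Among the compounds with values here, no measured pair isolates this kind of exchange on the sulfur, so the direction rests on the spread of the three numbers. Compound 1, which carries a larger fused heteroaryl on the same sulfur, gives 810 nM, the lowest number in the set. On that basis a move towards a lower number is expected for compound 4, but of modest size, with a result within the scatter of compound 2 not excluded; the estimated step is a 2.1-fold lower number from compound 2 to compound 4 (0.31 log units; beyond the scatter). For compound 4 the estimate in this assay is 1600 nM, with a range from 450 nM to 5500 nM.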

Compound 4, half-maximal inhibitory concentration: 4000 nM
Compound 4: middle estimate off by 2.5-fold (0.40 log units), on the low side; the measured number falls inside the stated range.
By their numbers in this assay, from the lowest: compound 1; then compounds 2 and 4 (each within the scatter of the next); then compound 3.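

In this assay, going by these compounds alone, the one step that isolates an exchange on this sulfur reads a 1.2-fold higher number from compound 2 to compound 4 (0.08 log units; within the scatter), so pyrimidin-2-yl and 5-phenyl-1H-1,2,4-triazol-3-yl cannot be told apart in this assay. The entering group adds heavy atoms, a second aromatic ring and a hydrogen-bond donor, yet in this single pair none of these additions comes with a difference beyond the scatter, and a larger aromatic group on the sulfur is therefore not enough by itself to give a lower number. No supporting data bear on the reason for this result.

The compounds shown leave open whether any group on this sulfur gives a step beyond the scatter when the rest of the molecule is held constant, for example a small methyl group or a triazole whose phenyl ring carries an amine or a carboxylic acid. Going by these compounds, it also remains open whether this same heteroaryl exchange would read alike with a longer chain on the urea nitrogen or with a different group on the other urea nitrogen.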